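Dichloropurine benzyl series: loss of a ring chloro

The source may report more compounds than this note shows. Statements on the series, on what has been measured and on what is new or still open speak of the compounds shown alone.

Measured so far:
compound 1 `ClCc1ccccc1Cn1cnc2c(Cl)nc(Cl)nc21` — 1200 nM
compound 2 `Nc1nc(Cl)c2ncn(Cc3ccc(CCl)cc3)c2n1` — 20000 nM

In a functional assay on HCT-15 cells (Homo sapiens) for cytotoxicity, read by sulforhodamine B assay, with a stated time of 48 h (on this read-out lower numbers stand for stronger inhibition of growth and higher numbers for weaker inhibition of growth), compound 1 gives 1200 nM, the lowest of the two numbers recorded. Compound 2 gives 20000 nM in this assay, a higher number that lies beyond the scatter; the two compounds differ in more than one place, so their two values alone say nothing about any single change.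

Compound 3 `ClCc1ccccc1Cn1cnc2c(Cl)ncnc21` is the next member. It differs from compound 1 in one place: hydrogen in place of chloro on an aromatic carbon. Among the measured compounds shown here, no measured pair isolates such a change, so the size of the step is open. Since compound 3 keeps the chloromethyl group and the remaining ring chloro of compound 1, only a modest weakening is expected, with a 2.1-fold higher number from compound 1 to compound 3 (0.32 log units; beyond the scatter) as the estimated step. For compound 3 the expected value in this assay is 2500 nM, in the range 800 nM to 8000 nM.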

Compound 3, concentration for total growth inhibition: 4670 nM
The estimate for compound 3 lay 1.9-fold (0.27 log units) below the measured number; the measured number falls inside the stated range.
By their numbers in this assay, from the lowest: compound 1; then compound 3; then compound 2.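

In this assay, among the compounds shown here, hydrogen in place of chloro on the aromatic carbon between two ring nitrogen atoms gives a 3.9-fold higher number from compound 1 to compound 3 (0.59 log units; beyond the scatter) as the first single-place step that can be read. In this one pair, the chloro at this position goes with stronger inhibition of growth, although the step is modest and compound 3 retains measurable activity without it. No available measurement explains the size of this step.

Going by these compounds, it remains open whether a methoxy group or a bromo at this position would stand nearer to compound 1 or to compound 3. On these data alone, the effect of replacing the remaining chloro, or of changing the chloromethyl group while the rest of compound 1 stays fixed, also remains open.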